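Fluoro to Methyl on the Aryl Ether of Compound 2

A few compounds are considered here, and "the series" means these few. Any claim that something is new, unique, unknown or untested is made for them only; others in the source may bear on it.

The three measured compounds were all tested in an assay on HEK293 cells for agonist activity at prostaglandin E2 receptor EP2 subtype (Homo sapiens), read by a beta-galactosidase reporter and beta-arrestin recruitment, with a stated time of 90 min; a higher number here means that more compound is needed for the effect, a lower number that less compound is needed.

Compound 1, `O=C(O)c1csc([C@H]2CC[C@@H]3[C@@H](COc4ccccc4F)[C@H](O)C[C@@H]3O2)n1`, gives only a limit of the assay: > 10000 nM.
Compound 2, `O=C(O)c1csc([C@H]2CC[C@@H]3[C@@H](COc4cccc(F)c4)[C@H](O)C[C@@H]3O2)n1`, also gives only a limit: > 10000 nM.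
Compound 3, `O=C(O)c1csc([C@H]2CC[C@@H]3[C@@H](CCCCCOc4ccccc4)[C@H](O)C[C@@H]3O2)n1`, with its longer chain to the phenoxy group, again gives only a limit: > 10000 nM.

Compound 2 therefore stands where every measured compound stands, at the limit; no number separates it from the others. For the measured compounds named here, the only single-point step among the measured compounds, a step that the two limits leave unreadable from compound 1 to compound 2, cannot be read, since both ends sit at the limit of > 10000 nM in this assay, at which 3 of the 3 values shown sit.

Compound 4, `Cc1cccc(OC[C@@H]2[C@H]3CC[C@H](c4nc(C(=O)O)cs4)O[C@H]3C[C@H]2O)c1`, differs from compound 2 by methyl in place of fluoro on an aromatic carbon. Going by the values given here, no measured step bears on this change in a readable way, and the one step that exists, from compound 1 to compound 2, stays hidden by the limit on both sides. With all values at the limit, there is no basis to expect compound 4 to depart from it; the estimated step from compound 2 to compound 4 in this assay is a step that the limit leaves unreadable from compound 2 to compound 4, essentially none. Compound 4 is thus expected to give about 20000 nM in this assay, within 5000 nM to 100000 nM, most likely reported again as a limit.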

Compound 4, half-maximal effective concentration: > 10000 nM
Compound 4: a limit, no number; the forecaster's own chance of this, stated with the estimate: 85%; the middle value does not contradict the limit.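

In this assay compound 4 gives > 10000 nM, which is a limit and not a number. For the compounds shown here, no step from compound 1 or compound 2 to compound 4 can be read, since all the values shown stand at: the limit of > 10000 nM in this assay, at which 4 of the 4 values shown sit.

The compounds shown leave open whether any change to the aryl ether or its chain would bring a measurable half-maximal effective concentration.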